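This account rests on a few compounds, and the source may have more. Where it says the series, first, only, none or still open, it means among the compounds named here.

In an ADME assay on MT4 cells (Homo sapiens) for cytotoxicity, read by spectrophotometry, with a stated time of 5 days (on this read-out higher numbers stand for lower toxicity in this test and lower numbers for higher toxicity in this test), compound 1 (`CN(C)CN1C(=O)/C(=N\NC(=S)NO)c2cc(F)ccc21`) gives 599000 nM, compound 2 (`Cc1ccc2c(c1)/C(=N/NC(=S)NO)C(=O)N2CN1CCN(c2ccc(Cl)cc2)CC1`) gives 335000 nM and compound 3 (`O=C1/C(=N\NC(=S)NO)c2cc(F)ccc2N1CN1CCN(c2ccc(Cl)cc2)CC1`) gives 194000 nM. Compound 3 thus lies within the scatter of compound 2, while compound 1 reads higher than compound 3 by more than the scatter. Compound 4 (`COc1ccc(N2CCN(CN3C(=O)/C(=N\NC(=S)NO)c4cc(F)ccc43)CC2)cc1`) differs from compound 3 by methoxy in place of chloro on an aromatic carbon. Within the data shown here, no measured step covers this exchange. Among the measured compounds shown here, the only step available is a 1.7-fold lower number from compound 2 to compound 3 (0.24 log units; within the scatter), a different exchange, fluoro in place of methyl, and it stays within the scatter. No step beyond the scatter is therefore expected in this assay. The estimated step is a 1.2-fold higher number from compound 3 to compound 4 (0.07 log units; within the scatter). For compound 4 the expected value is 230000 nM, with an estimated range from 100000 nM to 500000 nM.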

Compound 4, half-maximal cytotoxic concentration: 260000 nM
Compound 4: middle estimate off by 1.1-fold (0.05 log units), on the low side, and the stated range covers the measured number.
By their numbers in this assay, from the lowest: compounds 3, 4, 2 and 1 (each within the scatter of the next, the first and the last beyond it).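

In this assay, the exchange of 4-chlorophenyl for 4-methoxyphenyl gives a 1.3-fold higher number from compound 3 to compound 4 (0.13 log units; within the scatter), which stays within the scatter. Among these compounds, the earlier compounds with this aromatic ring all carried chloro at this carbon, para to a large group, so this is the only reading of a change there, and it shows no shift beyond the scatter. The compounds shown leave open how an amine, a carboxylic acid or a longer chain such as ethoxy would read at this carbon, and whether the exchange behaves alike with methyl in place of fluoro on the core. No measured evidence bears on this result.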